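Swapping methoxy for methyl on the phenyl ring

A few compounds are considered here, and "the series" means these few. Any claim that something is new, unique, unknown or untested is made for them only; others in the source may bear on it.

Measured so far:
- compound 1, `CCS[C@@H]1[C@H](SCC)[C@@H](Cn2cc(-c3ccccc3)nn2)O[C@H]1n1cc(C)c(=O)[nH]c1=O`: 1890 nM
- compound 2, `CCS[C@@H]1[C@H](SCC)[C@@H](Cn2cc(-c3ccc(OC)cc3)nn2)O[C@H]1n1cc(C)c(=O)[nH]c1=O`: 66000 nM

In a functional assay on HeLa cells (Homo sapiens) for cytotoxicity, read by MTT assay, with a stated time of 72 h (a lower number here means that less compound is needed, a higher number that more compound is needed for the effect), compound 2 gives 66000 nM, the highest of the two numbers measured; its nearest neighbour, compound 1, gives 1890 nM. For the measured compounds named here, the single step recorded so far, a 35-fold higher number from compound 1 to compound 2 (1.54 log units; beyond the scatter), comes from a methoxy in place of hydrogen on an aromatic carbon.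

Compound 3, `CCS[C@@H]1[C@H](SCC)[C@@H](Cn2cc(-c3ccc(C)cc3)nn2)O[C@H]1n1cc(C)c(=O)[nH]c1=O`, is not yet measured. It differs from compound 2 by methyl in place of methoxy on an aromatic carbon. Going by the values given here, no measured step covers a methyl at this position, so the only guidance is indirect: compound 1, with hydrogen there, gives 1890 nM, while compound 2, with methoxy, gives 66000 nM. A methyl sits between those two groups in what it brings, so the number for compound 3 is expected to fall between them, most likely below that of compound 2, with wide uncertainty. The expected step is therefore a 4.4-fold lower number from compound 2 to compound 3 (0.64 log units; beyond the scatter), and compound 3 is estimated at 15000 nM, within 3000 nM to 70000 nM.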

Compound 3, half-maximal effective concentration: 77500 nM
For compound 3 the middle estimate is 5.2-fold (0.71 log units) below the measured one, and the stated range ends below it.
By their numbers in this assay, from the lowest: compound 1; then compounds 2 and 3 (each within the scatter of the next).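

In this assay, the change from methoxy to methyl amounts to a 1.2-fold higher number from compound 2 to compound 3 (0.07 log units; within the scatter), so removing the oxygen of the methoxy group leaves no readable difference between these two compounds. Methyl in place of hydrogen gives a 41-fold higher number from compound 1 to compound 3 (1.61 log units; beyond the scatter), a large step of much the same kind as a 35-fold higher number from compound 1 to compound 2 (1.54 log units; beyond the scatter), so the rise first seen with methoxy is not unique to that group: among these three compounds, the one with hydrogen on this aromatic carbon stands apart, and the two with a substituent there sit together at much higher numbers. No accompanying measurement offers an explanation for this split.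

Three compounds cannot show whether any group at this spot brings the same large rise, or whether a fluorine, an amine or a carboxylic acid would stay closer to hydrogen. From the compounds shown here alone, it also remains open whether a longer chain such as ethoxy would match methyl and methoxy, and whether moving a methyl elsewhere on the phenyl ring would give a similar step.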